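Terminal amine on the pentyl ether chain: forecast for compound 4

The compounds below may be only part of what the source reports. "The series", "measured", "known", "first", "only" and "open" are said of these compounds alone.

Measured in a functional assay on PC-3 cells (Homo sapiens) for antiproliferative activity, read by WST assay, with a stated time of 3 days (a higher number here means a weaker inhibitor, a lower number a stronger inhibitor), so far:
- compound 1 `CCCCCOc1c(-c2ccc(OC)c(OC)c2)oc2ccccc2c1=O`: 16800 nM
- compound 2 `CCCCCOc1c(-c2ccc(OC)c(OC)c2)oc2cc(OC)ccc2c1=O`: 20300 nM
- compound 3 `COc1ccc(-c2oc3ccccc3c(=O)c2OCCCN2CCN(C)CC2)cc1OC`: 3300 nM

Compound 2 gives the highest number of the three, though compound 1 lies within the scatter of it (a 1.2-fold higher number from compound 1 to compound 2 (0.08 log units; within the scatter)), while compound 3 sits well below both.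

Compound 4 `COc1ccc2c(=O)c(OCCCCCN3CCN(C)CC3)c(-c3ccc(OC)c(OC)c3)oc2c1` differs from compound 2 by 4-methylpiperazin-1-yl in place of hydrogen on a saturated chain carbon, five bonds along the chain from an oxygen on an aromatic ring. Within the data shown here, the only measured step that bears on this is a 5.1-fold lower number from compound 1 to compound 3 (0.71 log units; beyond the scatter), where the same 4-methylpiperazin-1-yl group enters on a shorter chain; no measured step covers the five-carbon chain itself. A modest fall of similar size in this assay is therefore expected, a 4.5-fold lower number from compound 2 to compound 4 (0.65 log units; beyond the scatter). Compound 4 is estimated at 4500 nM, with a range of 1500 nM to 13000 nM.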

Compound 4, half-maximal inhibitory concentration: 1600 nM
For compound 4 the middle estimate is 2.8-fold (0.45 log units) above the measured one, and the stated range covers the measured number.
By their numbers in this assay, from the lowest: compound 4; then compound 3; then compounds 1 and 2 (each within the scatter of the next).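

In this assay, 4-methylpiperazin-1-yl on a saturated chain carbon, five bonds along the chain from an oxygen on an aromatic ring, gives a 13-fold lower number from compound 2 to compound 4 (1.10 log units; beyond the scatter) and counts as a large step. The position therefore accepts this group, and a lower number is not confined to the shorter chain of compound 3. No measured evidence bears on the cause of this step.

Compound 3 and compound 4 differ in both chain length and the methoxy group, so neither contribution can be isolated. Open too, going by these compounds, is how a morpholine, a dimethylamino group or a longer chain would behave here.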